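A few compounds are considered here, and "the series" means these few. Any claim that something is new, unique, unknown or untested is made for them only; others in the source may bear on it.

Compound 3, with the structure `N=C(NCCCc1c[nH]cn1)NCCC(c1ccc(F)cc1)c1cccnc1`, gives 7.91 in a functional assay on muscle tissue for agonist activity at histamine H2 receptor (Cavia porcellus); a lower number here means a less potent compound, a higher number a more potent compound, by a factor of ten per unit of this negative logarithm. That is the highest of the three measured numbers. Compound 1, `N=C(NCCCc1c[nH]cn1)NCCC(c1ccccc1)c1ccccn1`, gives 7.37 in this assay, and compound 2, `N=C(NCCCc1c[nH]cn1)NCCC(c1ccc(C(F)(F)F)cc1)c1ccccn1`, gives 7.23, both lying beyond the scatter below compound 3. Within the data shown here, the one single-point step among the measured compounds, a number 0.14 log units lower from compound 1 to compound 2 (within the scatter), is the trifluoromethyl in place of hydrogen on an aromatic carbon; it does not touch the pyridine at all. Compound 4, `N=C(NCCCc1c[nH]cn1)NCCC(c1ccccc1)c1ccc(F)cc1`, is compound 3 with phenyl in place of pyridin-3-yl on a saturated chain carbon bound to an aromatic carbon and a saturated chain carbon. Among the measured compounds shown here, no measured step speaks to this change. Compound 1 and compound 3 differ in two places at once, so only their two values can be set side by side. The pair of compounds 1 and 2 shows that a change on the phenyl ring leaves the number within the scatter, but exchanging the pyridine itself is a different matter. The replacement removes the one hydrogen-bond acceptor counted in the leaving group, and the expectation is a moderate loss, a number 0.71 log units lower from compound 3 to compound 4 (beyond the scatter). Compound 4 is therefore estimated at 7.2, within a range from 6.6 to 7.8.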

Compound 4, negative logarithm of the half-maximal effective concentration: 7.45
Compound 4: middle estimate off by 0.25 log units, on the low side; measured number inside the range.
By their numbers in this assay, from the lowest: compounds 2, 1 and 4 (each within the scatter of the next); then compound 3.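

In this assay, among these compounds, the exchange of phenyl for pyridin-3-yl on this saturated chain carbon, with the 4-fluorophenyl kept in place, gives a number 0.46 log units lower from compound 3 to compound 4 (beyond the scatter) and so provides the first step at this carbon, whereas the earlier single step lay on the phenyl ring and stayed within the scatter. On the same carbon, the exchange of 4-fluorophenyl for pyridin-2-yl, with the phenyl kept in place, gives a number 0.08 log units higher from compound 1 to compound 4 (within the scatter) and therefore does not move the number beyond the scatter, so removing a pyridine ring from this position does not have the same outcome in these two pairs. Nothing on hand accounts for this difference between the two exchanges.

The compounds shown do not settle whether pyridin-4-yl or pyrimidin-5-yl at this carbon would stand with pyridin-3-yl or with phenyl in this assay. They also leave open how pyridin-3-yl behaves with an unsubstituted phenyl as its partner, and whether a methoxy group in place of the fluorine on the phenyl ring would alter the picture.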